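Moving the Hydroxyl on a Shared Pyridine-Free Core Description

This account rests on a few compounds, and the source may have more. Where it says the series, first, only, none or still open, it means among the compounds named here.

Measured so far:
compound 1 `Oc1cccc(-c2cc(-c3cccc(C(F)(F)F)c3)cc(-c3cccc(O)c3)n2)c1` with 12700 nM in a functional assay on HeLa cells (Homo sapiens) for inhibition; on this read-out higher numbers stand for weaker inhibition and lower numbers for stronger inhibition;
compound 2 `Oc1cccc(-c2cc(-c3cccc(OC(F)(F)F)c3)cc(-c3ccccc3O)n2)c1` with 14900 nM in the same assay.

Among the two numbers recorded, compound 2 gives the highest value in this assay, with compound 1 nearest to it, and the gap between them lies within the usual scatter of this read-out. Within the data shown here, no step between two measured compounds that differ in a single place has been recorded, so there is nothing yet to set a scale for the change considered next.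

Compound 3 `Oc1cccc(-c2cc(-c3cccc(OC(F)(F)F)c3)cc(-c3cccc(O)c3)n2)c1` is built from compound 2 by one change: 3-hydroxyphenyl in place of 2-hydroxyphenyl on an aromatic carbon. The hydroxyl thus moves to the position it already holds in the other ring of the shared core.

Since compound 1, which carries two 3-hydroxyphenyl groups, gives 12700 nM, no step beyond the scatter is expected in this assay, and compound 3 is estimated at 12000 nM, between 4000 nM and 35000 nM, meaning an expected step of a 1.2-fold lower number from compound 2 to compound 3 (0.09 log units; within the scatter).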

Compound 3, half-maximal inhibitory concentration: > 50000 nM
Compound 3 ended at the assay's limit (the forecaster's own chance of this, stated with the estimate: 5%); middle value at least 4.1-fold (0.61 log units) from the limit.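

In this assay compound 3 stands at a limit of the assay and not at a number: the limit of > 50000 nM in this assay, at which 1 of the 3 values shown sits.

Exchanging 2-hydroxyphenyl for 3-hydroxyphenyl on the aromatic carbon next to the ring nitrogen gives an at least 3.3-fold higher number from compound 2 to compound 3 (0.52 log units; beyond the scatter), weaker inhibition, so with trifluoromethoxy in the core, the result at this place depends on where the hydroxyl stands. Trifluoromethoxy in place of trifluoromethyl, with both 3-hydroxyphenyl groups kept, gives an at least 3.9-fold higher number from compound 1 to compound 3 (0.59 log units; beyond the scatter), also weaker inhibition, which shows that this second place matters as well, something no earlier step could show.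

Going by these compounds, how far compound 3 lies past the limit stays unknown, so neither step has an exact size and the two cannot be ranked. Also open, on these data alone, is how an amine or a carboxylic acid in place of the hydroxyl on the 3-hydroxyphenyl group would read in this assay.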